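Swapping an Alkenyl Amide for a Cyclobutyl Amide

This account rests on a few compounds, and the source may have more. Where it says the series, first, only, none or still open, it means among the compounds named here.

Three amides on the shared core have been measured in a functional assay (Sus scrofa) with sulfonylurea receptors; K-ATP channels (Homo sapiens) as the target; on this read-out higher numbers stand for an effect only at larger amounts of compound and lower numbers for an effect already at smaller amounts. Compound 1 `CC(=O)Nc1c(C(O)(C(F)(F)F)C(F)(F)F)ccc2ccccc12` gives 95.5 nM, compound 2 `CC(C)=CC(=O)Nc1c(C(O)(C(F)(F)F)C(F)(F)F)ccc2ccccc12` gives 550 nM, and compound 3 `C/C=C/C(=O)Nc1c(C(O)(C(F)(F)F)C(F)(F)F)ccc2ccccc12` gives 49 nM. Compound 3 has the lowest number of the three: the step of a 1.9-fold lower number from compound 1 to compound 3 (0.29 log units; within the scatter) stays within the scatter, whereas the step of an 11-fold lower number from compound 2 to compound 3 (1.05 log units; beyond the scatter) is large, and the step of a 5.8-fold higher number from compound 1 to compound 2 (0.76 log units; beyond the scatter) is modest.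

Compound 4 `O=C(Nc1c(C(O)(C(F)(F)F)C(F)(F)F)ccc2ccccc12)C1CCC1` differs from compound 3 in one place: cyclobutyl in place of prop-1-en-1-yl on a carbonyl carbon. Going by the values given here, no measured step replaces a prop-1-en-1-yl with a ring, so the nearest guidance comes from the amide series itself. Compound 3 and compound 1 lie close together, while compound 2, which carries the 2-methylprop-1-en-1-yl, sits well apart from both. The cyclobutyl in compound 4 is neither of these groups, so a modest rise in the number is expected, as the step of a 3.1-fold higher number from compound 3 to compound 4 (0.49 log units; beyond the scatter). On this basis compound 4 is estimated at 150 nM in this assay, with a range from 50 nM to 500 nM.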

Compound 4, half-maximal effective concentration: 81.3 nM
Beside the measured number, compound 4's estimate is 1.8-fold (0.27 log units) above it, within the range that was stated.
By their numbers in this assay, from the lowest: compounds 3, 4 and 1 (each within the scatter of the next); then compound 2.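

In this assay, the position on the carbonyl carbon tolerates a ring: the step of a 1.7-fold higher number from compound 3 to compound 4 (0.22 log units; within the scatter) and the step of a 1.2-fold lower number from compound 1 to compound 4 (0.07 log units; within the scatter) leave compound 4 level with both compounds, so a double bond outside aromatic rings is not required here for a number in this range. Going by these compounds alone, the 2-methylprop-1-en-1-yl remains the only group of the four that stands apart, as the step of a 6.8-fold lower number from compound 2 to compound 4 (0.83 log units; beyond the scatter) shows, and so the cyclobutyl does not share the higher number of compound 2. Nothing available explains why these groups differ in this way.

On these data alone, whether a larger ring such as cyclohexyl would stay in this range remains open. So does the effect of a basic amine or a carboxylic acid on the cyclobutyl ring.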